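A few compounds are considered here, and "the series" means these few. Any claim that something is new, unique, unknown or untested is made for them only; others in the source may bear on it.

Measured so far:
- compound 1, `CCOC(=O)C(C)Sc1nc(Cl)cc(Nc2ccc3ncccc3c2)n1`: "not active" (no number reported)
- compound 2, `CCOC(=O)CSc1nc(Cl)cc(Nc2cccc3c2CCC3)n1`: 65.2%
- compound 3, `CCOC(=O)C(C)Sc1nc(Cl)cc(Nc2cccc(C)c2C)n1`: "not active" (no number reported)

Three compounds share one core and were tested in an assay for inhibition of Polyunsaturated fatty acid 5-lipoxygenase (Homo sapiens), tested at 1 uM; on this read-out lower numbers stand for a stronger effect and higher numbers for a weaker effect at the one concentration tested. Compound 1 gives "not active" (no number reported) in this assay, so no number is available for it; compound 3 likewise gives "not active" (no number reported). Only compound 2 has a number, 65.2%, which stands for a modest effect at the single concentration tested. Compound 1 therefore stands among the entries without a single number, and nothing in the data ranks it against the others.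

The step to be followed leads from compound 1 to compound 4, `CCOC(=O)C(Sc1nc(Cl)cc(Nc2ccc3ncccc3c2)n1)c1ccccc1`. The two differ in one place: phenyl in place of methyl on a saturated chain carbon bound to a carbonyl carbon and a sulfur. The methyl leaves the saturated chain carbon bound to a carbonyl carbon and a sulfur, and a phenyl takes its place there; the rest of the molecule is unchanged.

Going by the values given here, no step between measured compounds has been worked out, so there is nothing to lean on for the size of this change. With compound 1 giving "not active" (no number reported), the expectation in this assay is at most a small movement, not beyond the usual scatter, in either direction. Compound 4 is thus estimated at 85%, with an expected range from 55% to 105%.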

Compound 4, a percentage reported as activity, at one concentration (the size of the read-out at that concentration, not a potency): 52.7%
Beside the measured number, compound 4's estimate is 32.3 percentage points above it; measured number below the stated range.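

Compound 1 is reported as "not active" with no number, so the change from compound 1 to compound 4, phenyl in place of methyl, cannot be read as a step of any size. No supporting evidence bears on this result. The compounds shown leave open how much this exchange alters the effect on the enzyme.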